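The compounds below may be only part of what the source reports. "The series", "measured", "known", "first", "only" and "open" are said of these compounds alone.

Measured compounds:
- compound 1, `CC(=O)Nc1cccc(-c2ccc(C(O)(c3c[nH]cn3)C(C)C)cc2)c1`: 17 nM
- compound 2, `CC(=O)Nc1cccc(-c2ccc([C@](O)(c3c[nH]cn3)C(C)C)cc2)c1`: 14 nM
- compound 3, `CC(=O)Nc1cccc(-c2ccc([C@@](O)(c3c[nH]cn3)C(C)C)cc2)c1`: 770 nM

In an assay on microsomes from Testis (strain Sprague-Dawley) for inhibition of steroid 17-alpha-hydroxylase/17,20 lyase (Rattus norvegicus) (a lower number here means a stronger inhibitor, a higher number a weaker inhibitor), compound 1 gives 17 nM, the second highest of the three numbers. Its nearest neighbour is compound 2, reached by a 1.2-fold lower number from compound 1 to compound 2 (0.08 log units; within the scatter); its furthest is compound 3, reached by a 45-fold higher number from compound 1 to compound 3 (1.66 log units; beyond the scatter). Between the two drawn configurations the gap is a 55-fold higher number from compound 2 to compound 3 (1.74 log units; beyond the scatter), and the fact that compounds 2 and 3 differ only in the configuration as drawn places that whole difference on the stereocentre, while the fact that one of compounds 1 and 2 is drawn with a defined configuration and the other without, at the place where they differ and the fact that one of compounds 1 and 3 is drawn with a defined configuration and the other without, at the place where they differ show that compound 1 is drawn without a configuration at the same place.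

Compound 4, `CNS(=O)(=O)c1cccc(-c2ccc(C(O)(c3c[nH]cn3)C(C)C)cc2)c1`, differs from compound 1 by methylsulfamoyl in place of acetamido on an aromatic carbon, placed meta to a large group on the six-membered aromatic ring of carbon only. Among the compounds with values here, none of the three measured steps touches that part of the molecule; all of them concern the stereocentre alone, so no measured step bears directly on this exchange. The expectation for compound 4 in this assay therefore rests on compound 1 at 17 nM and on the wide spread seen across the set: compound 4 is expected at 30 nM, between 8 nM and 120 nM. That expected change amounts to a 1.8-fold higher number from compound 1 to compound 4 (0.25 log units; within the scatter).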

Compound 4, half-maximal inhibitory concentration: 71 nM
The estimate for compound 4 lay 2.4-fold (0.37 log units) below the measured number, and the stated range covers the measured number.
By their numbers in this assay, from the lowest: compounds 2 and 1 (each within the scatter of the next); then compound 4; then compound 3.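

Within the data shown here, putting methylsulfamoyl in place of acetamido on an aromatic carbon, meta to a large group, gives a 4.2-fold higher number from compound 1 to compound 4 (0.62 log units; beyond the scatter) in this assay, so this position, which the earlier compounds left unchanged, also affects the number. The effect is modest beside the stereocentre step, a 55-fold higher number from compound 2 to compound 3 (1.74 log units; beyond the scatter), and compound 1 and compound 4 are both drawn without a configuration at that centre, so the exchange is the only drawn difference between them. Nothing in the evidence at hand bears on why this exchange raises the number.

The compounds shown leave open whether the preference seen between the two drawn configurations also holds with methylsulfamoyl in place. They also leave open how a simple amine or a carboxylic acid would behave on this aromatic carbon.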